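The source may report more compounds than this note shows. Statements on the series, on what has been measured and on what is new or still open speak of the compounds shown alone.

Measured compounds:
compound 1 `Cc1ccccc1CN1CCc2c(sc(NC(=O)c3ccccc3Cl)c2C(N)=O)C1` — > 50000 nM
compound 2 `NC(=O)c1c(NC(=O)c2ccccc2Cl)sc2c1CCN(Cc1ccccc1Cl)C2` — 4430 nM

Both were tested in a functional assay on MKN-74 cells (Homo sapiens) for antiproliferative activity, with a stated time of 24 h; on this read-out lower numbers stand for stronger inhibition and higher numbers for weaker inhibition. For compound 1 the result is a limit of that assay, > 50000 nM, and not a number, so compound 1 stands at the limit of > 50000 nM in this assay, at which 1 of the 2 values shown sits. Compound 2 gives 4430 nM. Within the data shown here, the one step measured, an at least 11-fold lower number from compound 1 to compound 2 (1.05 log units; beyond the scatter), shows that a small exchange on this part of the molecule can move the read-out a long way.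

Compound 3 `COc1ccccc1NC(=S)N1CCc2c(sc(NC(=O)c3ccccc3Cl)c2C(N)=O)C1` is not yet measured. It differs from compound 1 in a larger way: a group of 11 heavy atoms (8 carbon, 1 nitrogen, 1 oxygen, 1 sulfur; one six-membered aromatic ring of carbon only) in place of a group of 8 heavy atoms (8 carbon; one six-membered aromatic ring of carbon only), on an amine nitrogen in a ring. The change to compound 3 removes the whole 2-methylbenzyl, the group whose methyl the step from compound 1 to compound 2 exchanged. Among the measured compounds shown here, that step is the only guide, and it covers a different and much smaller change, so the expected direction is uncertain, though a shift beyond the scatter is plausible. Compound 3 is therefore estimated at 20000 nM, within 3000 nM to 100000 nM, an expected step of an at least 2.5-fold lower number from compound 1 to compound 3 (0.39 log units; beyond the scatter).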

Compound 3, half-maximal inhibitory concentration: 35200 nM
The estimate for compound 3 lay 1.8-fold (0.25 log units) below the measured number, within the range that was stated.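

Compound 3 shows that the amine nitrogen in the ring can carry a quite different group from the 2-methylbenzyl, one that adds a double bond outside aromatic rings, and still give a measured number in this assay rather than a limit. Set against the chlorine-bearing group of the earlier series, this larger group gives a 7.9-fold higher number from compound 2 to compound 3 (0.90 log units; beyond the scatter) and so does not match it, which means the number at this position depends on more than the presence of an aromatic ring. The other step, an at least 1.4-fold lower number from compound 1 to compound 3 (0.15 log units; that floor lies within the scatter) cannot settle whether the new group improves on the 2-methylbenzyl, because compound 1 has only a limit: (the limit of > 50000 nM in this assay, at which 1 of the 3 values shown sits).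

Compound 3 changes both the aromatic ring and the link that joins it to the core at once, and the compounds shown leave open how much each of these contributes. They also leave open what a carboxylic acid or a longer chain on the amine nitrogen in the ring would do, and whether fluoro in place of the chloro of compound 2 would keep its number.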